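Cytotoxicity notes: exchanging the anilide arm of compound 3

A few compounds are considered here, and "the series" means these few. Any claim that something is new, unique, unknown or untested is made for them only; others in the source may bear on it.

Going by the values given here, the three measured members share one core. Compound 1 `Cc1ccccc1NC(=O)CSc1nncnc1-c1ccccc1Cl` gives 142000 nM in an ADME assay on MT4 cells (Homo sapiens) for cytotoxicity, read by MTT assay; a higher number here means that more compound is tolerated, a lower number that less compound is tolerated. Compound 2 `O=C(CSc1nncnc1-c1ccccc1Cl)Nc1ccccc1Cl` gives 90000 nM in this assay, and compound 3 `O=C(CSc1nncnc1-c1ccccc1Cl)Nc1cccnc1Cl` gives 167000 nM. Compound 3 thus carries the highest of the three numbers, yet both of its steps stay within the scatter: a 1.2-fold higher number from compound 1 to compound 3 (0.07 log units; within the scatter) and a 1.9-fold higher number from compound 2 to compound 3 (0.27 log units; within the scatter). Likewise a 1.6-fold lower number from compound 1 to compound 2 (0.20 log units; within the scatter). Exchanging the ring on the amide-type nitrogen has not moved the read-out beyond repeat variation in any measured case.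

Compound 4 `O=C(CSc1nncnc1-c1ccccc1Cl)c1ccc(Br)cc1Br` is not yet measured. Its change from compound 3 is 2,4-dibromophenyl in place of (2-chloropyridin-3-yl)amino on a carbonyl carbon. This differs in kind from the three measured steps: those kept the amide-type nitrogen and swapped only the aromatic ring on it, whereas here the nitrogen leaves together with its ring and a dibromophenyl ring attaches directly to the carbonyl carbon. The measured steps bear on it only loosely; all were within the scatter and give no basis for a direction. No measured step covers loss of the amide-type nitrogen, and the range is set wider for that reason alone. Compound 4 is expected near the level of compound 3, with an expected step of a 1.4-fold lower number from compound 3 to compound 4 (0.14 log units; within the scatter). The estimate for compound 4 in this assay is 120000 nM, with a range from 40000 nM to 300000 nM.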

Compound 4, half-maximal cytotoxic concentration: 28000 nM
Compound 4: the middle estimate sits 4.3-fold (0.63 log units) above what was measured, outside the stated range (below it).
By their numbers in this assay, from the lowest: compound 4; then compounds 2, 1 and 3 (each within the scatter of the next).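

In this assay the carbonyl carbon proves responsive where ring swaps on the amide-type nitrogen did not: 2,4-dibromophenyl in place of (2-chloropyridin-3-yl)amino gives a 6.0-fold lower number from compound 3 to compound 4 (0.78 log units; beyond the scatter) while the matching exchanges give a 3.2-fold lower number from compound 2 to compound 4 (0.51 log units; beyond the scatter) and a 5.1-fold lower number from compound 1 to compound 4 (0.71 log units; beyond the scatter) as well. All three steps lie beyond the scatter and point the same way, so less of compound 4 is tolerated than of any other compound shown, whereas compounds 1, 2 and 3 remain within the scatter of one another. Nothing available bears on the reason for this shift.

The change removes the amide-type nitrogen and replaces the ring in one step, so the compounds shown do not separate these two events: a 2,4-dibromophenyl ring kept on the amide-type nitrogen would test the ring alone, and a 2-chloropyridin-3-yl ring attached directly to the carbonyl carbon would test loss of the nitrogen alone. Also open, going by these compounds, is whether a simple amine or a carboxylic acid at this carbonyl carbon, with no aromatic ring, would stay level with compounds 1, 2 and 3.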